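This account rests on a few compounds, and the source may have more. Where it says the series, first, only, none or still open, it means among the compounds named here.

Measured so far:
compound 1, `CCCCn1nc(C(=O)N[C@H]2COc3ccccc3N(C)C2=S)nc1Cc1ccccc1`, 510 nM
compound 2, `CN1C(=S)[C@@H](NC(=O)c2nc(Cc3ccccc3)n(CCCF)n2)COc2ccccc21`, 4760 nM
compound 3, `CN1C(=S)[C@@H](NC(=O)c2nc(Cc3ccccc3)n(CCCC#N)n2)COc2ccccc21`, 2400 nM

All three were tested in a functional assay on HT-29 cells (Homo sapiens) for inhibition, read by luminescence and CellTiter-Glo, with a stated time of 24 h; on this read-out lower numbers stand for an effect already at smaller amounts and higher numbers for an effect only at larger amounts of compound. Compound 3 stands second highest of the three numbers: its nearest neighbour is compound 2, a 2.0-fold lower number from compound 2 to compound 3 (0.30 log units; within the scatter), while compound 1 lies furthest off, a 4.7-fold higher number from compound 1 to compound 3 (0.67 log units; beyond the scatter). Compound 4 `CN1C(=S)[C@@H](NC(=O)c2nc(Cc3ccccc3)n(C3CCN(C(=O)OC(C)(C)C)C3)n2)COc2ccccc21` is not yet measured. It differs from compound 3 in one place: a group of 12 heavy atoms (9 carbon, 1 nitrogen, 2 oxygen; one five-membered non-aromatic ring with 1 hetero atom) in place of a group of 5 heavy atoms (4 carbon, 1 nitrogen; no ring), on an aromatic nitrogen. The measured steps all concern the chain on that aromatic nitrogen: a 9.3-fold higher number from compound 1 to compound 2 (0.97 log units; beyond the scatter), a 4.7-fold higher number from compound 1 to compound 3 (0.67 log units; beyond the scatter) and a 2.0-fold lower number from compound 2 to compound 3 (0.30 log units; within the scatter). For the measured compounds named here, none swaps the chain for a ring, so the new group has no close precedent. Both changes away from the chain of compound 1 raised the number, so a return to that level seems unlikely. For compound 4 a number near compound 3, possibly higher, is expected: a 1.5-fold higher number from compound 3 to compound 4 (0.16 log units; within the scatter), giving 3500 nM within 800 nM to 15000 nM.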

Compound 4, half-maximal effective concentration: > 10000 nM
Compound 4 ended at the assay's limit; the forecaster's own chance of this, stated with the estimate: 15%; at least 2.8-fold (0.45 log units) between middle value and limit.
By their numbers in this assay, from the lowest: compound 1; then compounds 3 and 2 (each within the scatter of the next). At a limit, above all of these: compound 4.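

In this assay compound 4 reads > 10000 nM as a limit of the assay, not a number. Putting the larger ring-bearing group in place of the chains on the aromatic nitrogen gives an at least 4.1-fold higher number from compound 3 to compound 4 (0.61 log units; beyond the scatter) and an at least 2.1-fold higher number from compound 2 to compound 4 (0.32 log units; beyond the scatter) and an at least 19-fold higher number from compound 1 to compound 4 (1.29 log units; beyond the scatter) as its steps, so a position seen until now only with chains shows a clear rise in the number with this group. With a single ring-bearing group, the ring cannot be separated from what it carries. A plain cyclopentyl group, a ring with a free amine or a longer chain would help to separate them.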